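The source may hold more compounds than are shown below. What is called first, only, known or untested is meant among the compounds shown, and "the series" means these compounds.

Measured compounds:
- Compound 1 `O=C1c2ccccc2C(=O)N1CNc1ccc(Cl)cc1`: "not determined" (no result reported) in an assay on isolated protein for inhibition of ribosomal protein S6 kinase alpha-2 (Homo sapiens), read by fluorescence, with a stated time of 20 min; a lower number here means a stronger inhibitor, a higher number a weaker inhibitor
- Compound 2 `CCc1ccc(NCN2C(=O)c3ccccc3C2=O)cc1`: 4310 nM
- Compound 3 `COc1ccc(NCN2C(=O)c3ccccc3C2=O)cc1`: 470 nM

Going by the values given here, compound 2 stands highest of the two numbers available in this assay; the nearest entry is compound 3, and the only measured step that differs in one place is a 9.2-fold lower number from compound 2 to compound 3 (0.96 log units; beyond the scatter). Compound 1 shares the same core but has no result to set beside them.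

Compound 4 `O=C1c2ccccc2C(=O)N1CNc1ccc(O)cc1` differs from compound 2 by hydroxy in place of ethyl on an aromatic carbon. Among the compounds with values here, this change has no measured counterpart of its own. Within the data shown here, the step that bears on it is the one from compound 2 to compound 3, where an oxygen-bearing group replaced the ethyl at the same aromatic carbon and the number fell well beyond the scatter. With hydroxy entering at that position, a lower number in this assay is therefore expected for compound 4, of a size estimated at a 7.2-fold lower number from compound 2 to compound 4 (0.86 log units; beyond the scatter). Compound 4 is estimated at 600 nM, with a range from 200 nM to 2500 nM.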

Compound 4, half-maximal inhibitory concentration: 520 nM
Compound 4: middle estimate off by 1.2-fold (0.06 log units), on the high side; measured number inside the range.
By their numbers in this assay, from the lowest: compounds 3 and 4 (each within the scatter of the next); then compound 2.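

In this assay hydroxy in place of ethyl gives an 8.3-fold lower number from compound 2 to compound 4 (0.92 log units; beyond the scatter) and so repeats, with a second oxygen-bearing group, the drop first seen with methoxy at this aromatic carbon. Taking the methyl off that oxygen gives a 1.1-fold higher number from compound 3 to compound 4 (0.04 log units; within the scatter) and shows that, at this position, this assay cannot tell hydroxy and methoxy apart. Nothing measured here explains why either group differs from ethyl.

Going by these compounds, compound 1 carries a chlorine at this carbon but has no number to compare, so it is still open whether oxygen matters here or whether other groups replacing ethyl would do the same. An amine at this carbon, or a longer chain on the oxygen such as ethoxy, would help to separate those possibilities.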